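Methoxy to Ethoxy on a Free Fatty Acid Receptor 1 Agonist

The source may hold more compounds than are shown below. What is called first, only, known or untested is meant among the compounds shown, and "the series" means these compounds.

Measured compounds:
- compound 1 `Cc1cc(OCc2cccc(-c3c(C)cc(OCCCS(C)(=O)=O)cc3C)c2)ccc1N(CC(=O)O)C(=O)c1ccccc1`: "not determined" (no result reported)
- compound 2 `COc1cc(C)c(-c2cccc(COc3ccc(OCC(=O)O)c(F)c3)c2)c(C)c1`: 49.7 nM
- compound 3 `Cc1cc(OCCCS(C)(=O)=O)cc(C)c1-c1cccc(COc2ccc(N(CC(=O)O)C(=O)c3ccoc3)cc2)c1`: "not determined" (no result reported)

Three compounds from the study share a biaryl ether scaffold carrying a carboxylic acid, but only one of them comes with a number. In a functional assay on CHO cells for agonist activity at Free fatty acid receptor 1 (Homo sapiens), read by FLIPR and calcium flux (on this read-out lower numbers stand for an effect already at smaller amounts and higher numbers for an effect only at larger amounts of compound), compound 2 gives 49.7 nM. Among the measured compounds shown here, for compound 1 and compound 3 no result was reported in this assay, so compound 2 stands alone as the sole reference point; it cannot be ranked against the other two, and no step between measured compounds is available.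

The unmeasured compound 4 `CCOc1cc(C)c(-c2cccc(COc3ccc(OCC(=O)O)c(F)c3)c2)c(C)c1` is the closest relative of compound 2. The difference between them is methyl in place of hydrogen on a saturated chain carbon bound to an oxygen on an aromatic ring. Put another way, the methoxy on the outer ring of compound 2 becomes an ethoxy in compound 4, and nothing else changes.

For the measured compounds named here, with no measured step to lean on, the expectation rests on the small size of this change. The step of a 1.1-fold lower number from compound 2 to compound 4 (0.04 log units; within the scatter) is expected to stay within the usual scatter of repeated measurements, with no clear direction. Compound 4 is therefore estimated at 45 nM in this assay, with a plausible range from 20 nM to 110 nM.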

Compound 4, half-maximal effective concentration: 65.9 nM
For compound 4 the middle estimate is 1.5-fold (0.17 log units) below the measured one, within the range that was stated.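

In this assay, among the compounds shown here, the step of a 1.3-fold higher number from compound 2 to compound 4 (0.12 log units; within the scatter) lies within the scatter, and it is the first step in this set that can be read at all. It shows that this position, a saturated chain carbon bound to an oxygen on an aromatic ring, accepts methyl in place of hydrogen without any difference that the assay can separate from repeat measurements, so methoxy and ethoxy on the outer ring cannot be told apart here, something a single value for compound 2 could not show. Nothing in the material accounts for this result, and it offers no measured property of either group that bears on it.

The compounds shown leave open whether the same position would stay as undemanding with a longer chain such as butoxy, with a ring such as cyclopropyl, or with an amine at the end of the chain, since one added methyl marks only the smallest possible extension. They also leave open whether the methoxy to ethoxy change would read the same way on the core of compound 1 or compound 3, where the acid side of the molecule is different.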